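A few compounds are considered here, and "the series" means these few. Any claim that something is new, unique, unknown or untested is made for them only; others in the source may bear on it.

Compound 1 `COc1cc(OC)c(C(=O)/C=C/c2ccc(C(F)(F)F)cc2)c(O)c1CC=C(C)C`: 73700 nM
Compound 2 `CCCCCc1c(OC)cc(OC)c(C(=O)/C=C/c2cccc(N3CCNCC3)c2)c1O`: > 100000 nM (a limit)

Both compounds were tested in an ADME assay on MCF7-DOX cells (Homo sapiens) for cytotoxicity, read by MTT assay, with a stated time of 48 h; a lower number here means a stronger inhibitor, a higher number a weaker inhibitor. In this test, compound 2 gives > 100000 nM, which is a limit of the assay and not a number. Compound 2 therefore stands at the limit of > 100000 nM in this assay, at which 1 of the 2 values shown sits. For the measured compounds named here, compound 1 gives 73700 nM, the only true number so far. Going by the values given here, compounds 1 and 2 differ in more than one place, so no measured step isolates a single change.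

Compound 3 `CCCCc1c(OC)cc(OC)c(C(=O)/C=C/c2cccc(N3CCNCC3)c2)c1O` has not yet been measured. It differs from compound 2 in one place: hydrogen in place of methyl on a saturated chain carbon, four bonds along the chain from an aromatic carbon, which means hydrogen in place of methyl on a saturated chain carbon, four bonds along the chain from an aromatic carbon. Among the compounds with values here, with no measured step as a guide, this small change is expected to produce no shift beyond the scatter in this assay, in either direction. The number for compound 1, 73700 nM, also sits high on the scale, so a weak result is expected. Compound 3 may again return only a limit. The expected change is an at least 1.1-fold lower number from compound 2 to compound 3 (0.04 log units; that floor lies within the scatter). Compound 3 is estimated at 90000 nM, with an expected range of 40000 nM to 160000 nM.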

Compound 3, half-maximal inhibitory concentration: > 100000 nM
Compound 3 gave a limit, no number; the forecaster's own chance of this, stated with the estimate: 45%; middle value at least 1.1-fold (0.04 log units) from the limit.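

Compound 2 and compound 3 each return only a limit in this assay, not a number, so no new step can be read between them. The compounds shown leave open what number either compound would give, and so how far hydrogen in place of methyl on the chain moves the result: the limit of > 100000 nM in this assay, at which 2 of the 3 values shown sit.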